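Reversing the amide on the shared core of compound 1

The source may hold more compounds than are shown below. What is called first, only, known or untested is meant among the compounds shown, and "the series" means these compounds.

Measured compounds:
Compound 1 `CCCC(=O)Nc1cccc(NC(=O)c2ccccc2Cl)c1` — 1100 nM in an assay on a cell-free system (plasma) for inhibition of proteinase-activated receptor 1 (Homo sapiens), read by flow cytometry, with a stated time of 20 min; on this read-out lower numbers stand for stronger inhibition and higher numbers for weaker inhibition
Compound 2 `CCCC(=O)Nc1cccc(NC(=O)c2cccc(Cl)c2Cl)c1` — 3120 nM

Among the compounds with values here, compound 1 gives the lowest number of the two, and the only other compound sits at a 2.8-fold higher number from compound 1 to compound 2 (0.45 log units; beyond the scatter). Compound 3 `CCCNC(=O)c1cccc(NC(=O)c2ccccc2Cl)c1` has not been measured. It differs from compound 1 by propylcarbamoyl in place of (propylcarbonyl)amino on an aromatic carbon. Within the data shown here, no measured step bears on such a reversal of the amide: the single step, a 2.8-fold higher number from compound 1 to compound 2 (0.45 log units; beyond the scatter), concerns a chloro group elsewhere and offers no guide here. Compound 3 is therefore estimated with wide uncertainty at 2200 nM, between 500 nM and 9000 nM, a step of a 2.0-fold higher number from compound 1 to compound 3 (0.30 log units; within the scatter).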

Compound 3, half-maximal inhibitory concentration: 1800 nM
Compound 3: middle estimate off by 1.2-fold (0.09 log units), on the high side; the measured number falls inside the stated range.
By their numbers in this assay, from the lowest: compounds 1, 3 and 2 (each within the scatter of the next, the first and the last beyond it).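

Reversing the amide, with propylcarbamoyl in place of (propylcarbonyl)amino on an aromatic carbon, gives a 1.6-fold higher number from compound 1 to compound 3 (0.21 log units; within the scatter) and so shows that, for this pair, the direction of the amide at this position leaves the number within the scatter. The two groups have the same atoms, joined differently. Nothing available bears on why the reversal is tolerated here.

On these data alone, whether a longer chain or a terminal amine or carboxylic acid on the reversed amide would keep the number stays open. So does whether the step of a 2.8-fold higher number from compound 1 to compound 2 (0.45 log units; beyond the scatter) for the added chloro would repeat on compound 3.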